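Aryl exchange at the hydrazone carbon: compound 3

This account rests on a few compounds, and the source may have more. Where it says the series, first, only, none or still open, it means among the compounds named here.

Among the compounds with values here, compound 2 `CC1=CC[C@@H]([C@@](C)(O)CCCC(C)(C)NC(=S)N/N=C\c2cccc([N+](=O)[O-])c2)CC1` gives 560 nM in a functional assay on K562 cells (Homo sapiens) for cytotoxicity, read by sulforhodamine B assay (on this read-out higher numbers stand for weaker inhibition of growth and lower numbers for stronger inhibition of growth), and holds the lowest of the two numbers measured so far. Compound 1 `COc1ccc(/C=N\NC(=S)NC(C)(C)CCC[C@](C)(O)[C@@H]2CC=C(C)CC2)cc1` gives 34900 nM in this assay. Within the data shown here, the one comparable pair shows a 62-fold lower number from compound 1 to compound 2 (1.79 log units; beyond the scatter), so an exchange of the aryl group on the carbon with a double bond to nitrogen has already moved the read-out a great deal.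

Compound 3 `CC1=CC[C@@H]([C@@](C)(O)CCCC(C)(C)NC(=S)N/N=C\c2ccccc2Cl)CC1` is still to be measured. Relative to compound 2 the change is 2-chlorophenyl in place of 3-nitrophenyl on a carbon with a double bond to nitrogen. Among the measured compounds shown here, no measured step covers this exact exchange; the only step in hand, from compound 1 to compound 2, swaps one aryl group for another at the same place and was large. It shows that this place can move the number strongly, but not in which direction a 2-chlorophenyl will move it. As compound 2 holds the lowest number in the set, more room lies toward higher numbers. For compound 3 the expected step is a 5.4-fold higher number from compound 2 to compound 3 (0.73 log units; beyond the scatter) in this assay. Compound 3 is estimated at 3000 nM, with a range from 600 nM to 15000 nM.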

Compound 3, concentration for total growth inhibition: 4110 nM
For compound 3 the middle estimate is 1.4-fold (0.14 log units) below the measured one, and the stated range covers the measured number.
By their numbers in this assay, from the lowest: compound 2; then compound 3; then compound 1.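

With a third aryl group on the carbon with a double bond to nitrogen, this assay gives a graded series rather than a split between one favourable group and the rest: there is a 7.3-fold higher number from compound 2 to compound 3 (0.87 log units; beyond the scatter), and also an 8.5-fold lower number from compound 1 to compound 3 (0.93 log units; beyond the scatter), so all three compounds are separated by steps beyond the scatter. The second of these steps shows that a nitro group is not required for a number lower than that of compound 1, since the 2-chlorophenyl of compound 3 carries none, although 3-nitrophenyl remains the lowest of the three aryl groups shown. No measured evidence bears on why the three aryl groups rank in this order.

The three aryl groups differ both in the substituent and in where it sits on the ring, so these compounds cannot separate the two contributions, and the core stays the same throughout. Open at this same place are an unsubstituted phenyl and aryl rings bearing a nitrile or an amine, which would show whether any ring substituent is needed and how far the number can fall below that of compound 2.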